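The source may report more compounds than this note shows. Statements on the series, on what has been measured and on what is new or still open speak of the compounds shown alone.

In a functional assay on a cell-free system (Platelet, plasma, Homo sapiens) for inhibition (on this read-out higher numbers stand for weaker inhibition and lower numbers for stronger inhibition), compound 1 `COc1ccc(NC(=O)C2CCCNC2)cc1` gives 983000 nM, and compound 2 `O=C(Nc1cccc(OCc2ccc(-c3ccccc3)cc2)c1)C1CCCNC1` gives 153000 nM. Within the data shown here, compound 3 `O=C(Nc1cccc(OCc2ccc(-c3ccc(F)cc3)cc2)c1)C1CCNCC1` gives 35000 nM, the lowest number of the three and so the strongest inhibition measured so far. Its gaps to both other compounds lie beyond the scatter. Among the measured compounds shown here, no two measured compounds differ in one place only, so the series offers no direct measure of any single change.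

Compound 4 `O=C(Nc1cccc(OCc2ccc(-c3ccc(C(F)(F)F)cc3)cc2)c1)C1CCNCC1` has not yet been measured. It carries trifluoromethyl in place of fluoro on an aromatic carbon, para to a large group: trifluoromethyl in place of fluoro on an aromatic carbon. For the measured compounds named here, with no measured precedent for this change, the expectation stays anchored on compound 3 at 35000 nM. The expected 1.2-fold lower number from compound 3 to compound 4 (0.07 log units; within the scatter) stays within the scatter, with only a slight lean toward stronger inhibition. For compound 4 the estimated value in this assay is 30000 nM, with an expected range of 10000 nM to 90000 nM.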

Compound 4, half-maximal inhibitory concentration: 65700 nM
For compound 4 the middle estimate is 2.2-fold (0.34 log units) below the measured one; the range from low to high includes it.
By their numbers in this assay, from the lowest: compounds 3 and 4 (each within the scatter of the next); then compound 2; then compound 1.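

In this assay, among these compounds, the step of a 1.9-fold higher number from compound 3 to compound 4 (0.27 log units; within the scatter) is the first comparison that differs in one place only, and it gives a direct reading for this aromatic carbon, para to a large group. At this position, 4-fluorophenyl and 4-(trifluoromethyl)phenyl cannot be separated on this read-out, so exchanging fluoro for trifluoromethyl gives no measurable shift in inhibition in this one pair. No measurement on hand bears on the reason for this result.

Among the compounds shown here, whether any group at this position would move the number beyond the scatter remains open, since the series holds no pair with an amine, a carboxylic acid or a longer chain there. The gaps among compounds 1, 2 and 3 cannot be read as single steps, as those compounds differ in more than one place.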